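The source may report more compounds than this note shows. Statements on the series, on what has been measured and on what is new or still open speak of the compounds shown alone.

Working notes on the series.

Compound 3 `CCCNC(=O)c1c(NC(=O)NS(=O)(=O)c2ccccc2)sc2c1CCCCC2` is one of three compounds made on a shared core that carry a sulfonylurea. In a functional assay on UACC-257 cells (Homo sapiens) for inhibition, with a stated time of 48 h (a higher number here means a weaker inhibitor of growth, a lower number a stronger inhibitor of growth), compound 3 gives > 100000 nM, which is a limit of the assay and not a number. Compound 1 `O=C(Nc1sc2c(c1C(=O)NNc1ccc(Br)cc1)CCCCC2)NS(=O)(=O)c1ccccc1` gives in this assay > 100000 nM, also a limit. Compound 2 `O=C(Nc1sc2c(c1C(=O)NNc1ccc(Cl)cc1)CCCCC2)NS(=O)(=O)c1ccccc1` gives in this assay > 100000 nM, again a limit. The steps a step that the two limits leave unreadable from compound 1 to compound 2, a step that the two limits leave unreadable from compound 1 to compound 3 and a step that the two limits leave unreadable from compound 2 to compound 3 are all unreadable for this reason: every value sits at the limit of > 100000 nM in this assay, at which 3 of the 3 values shown sit. Compound 3 therefore stands at the top limit together with the other two, and no ordering among them can be given.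

Compound 4 `O=C(Nc1sc2c(c1C(=O)N1CCN(c3ccccc3)CC1)CCCCC2)NS(=O)(=O)c1ccccc1` is derived from compound 3 through (4-phenylpiperazin-1-yl in place of propylamino on a carbonyl carbon). Going by the values given here, none of the measured steps bears on this change in a readable way; the only information is that three different substituents on the carbonyl carbon, including both arylhydrazide groups and the propylamino group, all left growth inhibition at the limit. The same outcome is expected for compound 4. Compound 4 is estimated to give 100000 nM in this assay, within 30000 nM to 300000 nM. This corresponds to an expected step of a number no higher from compound 3 to compound 4 (the limit leaves the size open), most likely again reported only as a limit.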

Compound 4, concentration for 50% growth inhibition: > 100000 nM
Compound 4 was reported as a limit; the forecaster's own chance of this, stated with the estimate: 80%; the middle value sits exactly at the limit.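

No step from compound 1, compound 2 or compound 3 to compound 4 can be read, because all four values are limits: the limit of > 100000 nM in this assay, at which 4 of the 4 values shown sit.

The compounds shown leave open how these four rank in this assay, and whether any group on the carbonyl carbon gives a readable value there.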